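This account rests on a few compounds, and the source may have more. Where it says the series, first, only, none or still open, it means among the compounds named here.

Measured so far:
compound 1 `COc1cc(-c2cc(/C=C/C(=O)c3ccc(N)cc3)[nH]n2)cc(OC)c1OC` — in a functional assay on LOX IMVI cells (Homo sapiens) for cytotoxicity, read by sulforhodamine B assay, with a stated time of 48 h, tested at 0.1 uM (on this read-out higher numbers stand for a weaker effect at the one concentration tested and lower numbers for a stronger effect), compound 1 gives 99%
compound 2 `COc1ccc(-c2cc(/C=C/C(=O)c3ccc(N)cc3)[nH]n2)cc1OC` — in this assay compound 2 gives 102%

Compound 1 stands alongside compound 2, the two parted only by a number 3 percentage points higher from compound 1 to compound 2 (within the scatter); neither shows a marked effect at the concentration tested.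

Compound 3 `COc1ccc(C(=O)/C=C/c2cc(-c3cc(OC)c(OC)c(OC)c3)n[nH]2)cc1` is not yet measured. Relative to compound 1 the change is methoxy in place of amino on an aromatic carbon. Within the data shown here, no measured step covers this exchange: the one known step, a number 3 percentage points higher from compound 1 to compound 2 (within the scatter), concerns hydrogen in place of methoxy on the other ring and stayed within the scatter. With both measured compounds near full activity, compound 3 is expected to move by no change at the digits printed from compound 1 to compound 3 (within the scatter), nothing beyond the scatter. For compound 3 the estimate in this assay is 99%, range 88% to 110%.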

Compound 3, a percentage reported as activity, at one concentration (the size of the read-out at that concentration, not a potency): 93%
Beside the measured number, compound 3's estimate is 6 percentage points above it, within the range that was stated.
By their numbers in this assay, from the lowest: compounds 3, 1 and 2 (each within the scatter of the next).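

In this assay, among these compounds, the exchange of 4-aminophenyl for 4-methoxyphenyl gives a number 6 percentage points lower from compound 1 to compound 3 (within the scatter), the first reading at this position, para to a large group, since the earlier step concerned the other ring. At the one concentration tested, the amino group and its hydrogen-bond donor can therefore give way to methoxy with no shift beyond the scatter. No available measurement offers an explanation for this result.

On these data alone, whether a carboxylic acid or a dimethylamino group at this position would read differently remains open. So does how these compounds behave at higher concentrations.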